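Isopropyl in Place of Methyl: What to Expect for Compound 4

A few compounds are considered here, and "the series" means these few. Any claim that something is new, unique, unknown or untested is made for them only; others in the source may bear on it.

Compound 1, `C[C@H](Nc1ncnc2[nH]cnc12)c1nn(-c2cccnc2)c2cc(F)ccc12`: 20%
Compound 2, `C[C@H](Nc1ncnc2[nH]cnc12)c1nn(-c2ccccn2)c2cc(F)ccc12`: 12%
Compound 3, `C[C@H](Nc1ncnc2[nH]cnc12)c1nn(-c2ccncc2)c2cc(F)ccc12`: 5%

Of the compounds shown here, three sharing one core have been tested in a functional assay on Hep 3B2 cells (Homo sapiens) for inhibition, read by sulforhodamine B assay, with a stated time of 72 h, tested at 10 uM; on this read-out higher numbers stand for more inhibition at the one concentration tested (going by the name of the read-out) and lower numbers for less inhibition. In this assay compound 1 gives 20%. Compound 2 gives 12%, and compound 3 gives 5%. Within the data shown here, compound 1 stands highest of the three numbers, but only one of its neighbours lies clearly away from it: the step of a number 8 percentage points lower from compound 1 to compound 2 (within the scatter) stays within the scatter, whereas a number 15 percentage points lower from compound 1 to compound 3 (beyond the scatter) goes beyond it, if modestly. The remaining step, a number 7 percentage points lower from compound 2 to compound 3 (within the scatter), is again within the scatter.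

Compound 4, `CC(C)[C@H](Nc1ncnc2[nH]cnc12)c1nn(-c2cccnc2)c2cc(F)ccc12`, has not yet been measured. It differs from compound 1 in a single place: isopropyl in place of methyl on a saturated chain carbon bound to an aromatic carbon and a nitrogen on an aromatic ring. Among the measured compounds shown here, every measured step so far alters the group on an aromatic nitrogen; none of them alters the saturated chain carbon bound to an aromatic carbon and a nitrogen on an aromatic ring, so no measured step bears directly on this change. Without such a precedent, the most defensible expectation is a step of no clear size in either direction, and the estimated step of no change at the digits printed from compound 1 to compound 4 (within the scatter) is meant to stay within the scatter. Compound 4 is therefore expected to give about 20%, with a likely range from 5% to 40%.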

Compound 4, a percentage reported as inhibition, at one concentration (the size of the read-out at that concentration, not a potency): 4%
Compound 4: middle estimate off by 16 percentage points, on the high side, and the stated range ends above it.
By their numbers in this assay, from the lowest: compounds 4, 3, 2 and 1 (each within the scatter of the next, the first and the last beyond it).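

In this assay, the saturated chain carbon bound to an aromatic carbon and a nitrogen on an aromatic ring proves to be a place where a change can move the read-out: isopropyl in place of methyl, with 3 heavy atoms instead of 1, gives a number 16 percentage points lower from compound 1 to compound 4 (beyond the scatter), a modest step that lies beyond the scatter. Among these compounds, the earlier compounds could not show this, as all of them carry methyl here and differ only in the group on an aromatic nitrogen, so this is the first sign that the chain carbon matters as well. Nothing in the data shown gives a reason for this step.

As far as these compounds go, with only methyl and isopropyl at this place, it remains open how the number would respond to ethyl, to a cyclopropyl ring or to a hydroxymethyl group, and so whether the fall simply follows the count of carbons. From the compounds shown here alone, it also remains open whether isopropyl would give a similar step with pyridin-2-yl or pyridin-4-yl on the aromatic nitrogen, rather than the pyridin-3-yl group of compound 1.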